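Cytotoxicity limits across a urea series on a shared core

A few compounds are considered here, and "the series" means these few. Any claim that something is new, unique, unknown or untested is made for them only; others in the source may bear on it.

Compound 1 `COc1ccc(NC(=O)Nc2cc(C)nc3ccccc23)cc1` and compound 2 `Cc1cc(NC(=O)Nc2ccccc2C(F)(F)F)c2ccccc2n1` share one core and were tested in an ADME assay on HepG2 cells (Homo sapiens) for cytotoxicity, with a stated time of 72 h; on this read-out higher numbers stand for an effect only at larger amounts of compound and lower numbers for an effect already at smaller amounts. In this assay compound 1 gives a limit of > 25000 nM, not a number. Compound 2 likewise gives a limit of > 25000 nM. Compound 1 therefore stands at the limit of > 25000 nM in this assay, at which 2 of the 2 values shown sit, with no measured value placing it anywhere inside the range. Compound 3 `COC(=O)c1ccc(NC(=O)Nc2cc(C)nc3ccccc23)cc1` differs from compound 1 by methoxycarbonyl in place of methoxy on an aromatic carbon. For the measured compounds named here, no measured step between two compounds exists, so the change is expected to give no step beyond the scatter, a step that the limit leaves unreadable from compound 1 to compound 3. Compound 3 is estimated at 40000 nM, between 15000 nM and 100000 nM, most likely again reported only as a limit.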

Compound 3, half-maximal effective concentration: 20000 nM
Beside the measured number, compound 3's estimate is 2.0-fold (0.30 log units) above it; low and high end bracket the measured number.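

For the compounds shown here, compound 3 gives the only number rather than a limit in this assay so far, 20000 nM, so a cytotoxic effect on this read-out can be reached on the shared core. Methoxycarbonyl in place of methoxy, para to a large group, gives an at least 1.2-fold lower number from compound 1 to compound 3 (0.09 log units; that floor lies within the scatter). The full size of this step cannot be read because compound 1 stands at a limit: the limit of > 25000 nM in this assay, at which 2 of the 3 values shown sit.

From the compounds shown here alone, whether a carboxylic acid, an amine or a longer ester chain on this aromatic carbon would move the number beyond the scatter from compound 3 stays open.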